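From methoxy to chloro at a limit of cytotoxicity

A few compounds are considered here, and "the series" means these few. Any claim that something is new, unique, unknown or untested is made for them only; others in the source may bear on it.

Values in an ADME assay on HL-60 cells (Homo sapiens) for cytotoxicity, read by MTT assay, with a stated time of 24 h (on this read-out higher numbers stand for weaker inhibition and lower numbers for stronger inhibition), are shown below, and each one is a limit.
Compound 1 `CC(C)CN(C)Cc1ccc(C2=CCCN(C)C2)cc1` gives > 50000 nM as a limit
Compound 2 `CC(C)CCCN(C)Cc1ccc(C2=CCCN(C)C2)cc1` gives > 50000 nM as a limit
Compound 3 `COc1ccc(CN(C)Cc2ccc(C3=CCCN(C)C3)cc2)cc1` gives > 50000 nM as a limit

Compound 3 thus stands at a limit and has no number. The series as a whole offers the limit of > 50000 nM in this assay, at which 3 of the 3 values shown sit, and nothing finer. Compound 4 `CN1CCC=C(c2ccc(CN(C)Cc3ccc(Cl)cc3)cc2)C1` keeps the rest of compound 3 but carries chloro in place of methoxy on an aromatic carbon, para to a large group, so that 4-methoxyphenyl becomes 4-chlorophenyl chloro in place of methoxy on an aromatic carbon in this single change.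

Within the data shown here, no measured step makes this exact exchange. The nearest evidence is a step that the two limits leave unreadable from compound 1 to compound 3 together with a step that the two limits leave unreadable from compound 2 to compound 3 and neither has a readable size. The same holds for a step that the two limits leave unreadable from compound 1 to compound 2 in the remaining pair. With no size to carry over, no step beyond the usual scatter is expected in this assay and no direction can be favoured. The expected change is a number no higher from compound 3 to compound 4 (the limit leaves the size open) and this remains an estimate resting on a limit. Compound 4 is expected at 50000 nM with an estimated range from 20000 nM to 100000 nM and the reading may well be only a limit again.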

Compound 4, half-maximal inhibitory concentration: > 50000 nM
Compound 4: no number, only a limit; the forecaster's own chance of this, stated with the estimate: 75%; the middle value lies on the limit itself.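

Compound 4 also reads only as a limit in this assay, so its steps from compound 1, compound 2 and compound 3 cannot be read. The compounds shown leave open whether any of these changes shifts the read-out at all, and by how much, since every reading stops at the same point: the limit of > 50000 nM in this assay, at which 4 of the 4 values shown sit.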